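The compounds below may be only part of what the source reports. "The series", "measured", "known", "first", "only" and "open" are said of these compounds alone.

Measured so far:
compound 1 `CC(C)(C)C(=O)N1N=CCC1c1c[nH]cn1` — 1.7
compound 2 `O=C(c1cn[nH]c1)N1CCC(C(=O)N2N=CCC2c2ccccc2)CC1` — 2.1
compound 3 `O=C(C1CCC1)N1N=CCC1c1ccccc1` — 4.7

These three values come from a physicochemical assay for lipophilicity, read by HPLC, measured as chromatographic lipophilicity, at pH 7.4; on this read-out lower numbers stand for lower lipophilicity and higher numbers for higher lipophilicity. Among them compound 3 stands highest: compound 2, the nearest, lies a long way below it, and compound 1 lower still, both gaps well beyond the usual scatter of this assay. The account now turns to compound 4 `CC(C)(CO)C(=O)N1N=CCC1c1ccccc1`, not yet measured. It differs from compound 3 in one place: 1-(hydroxymethyl)-1-methylethyl in place of cyclobutyl on a carbonyl carbon. Within the data shown here, no measured pair shows this particular change, so the expected step rests on the change alone. A sizeable downward step in this assay is expected, a number 1.20 log units lower from compound 3 to compound 4 (beyond the scatter), because compound 3 sits at 4.7 and the entering group brings a hydroxyl where the leaving cyclobutyl had none. Compound 4 is therefore estimated at 3.5, within a range from 2.8 to 4.2.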

Compound 4, distribution coefficient: 3.4
The estimate for compound 4 lay 0.10 log units above the measured number, and the stated range covers the measured number.
By their numbers in this assay, from the lowest: compound 1; then compound 2; then compound 4; then compound 3.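

In this assay, this position now has its first readable single-place step: a number 1.30 log units lower from compound 3 to compound 4 (beyond the scatter) when 1-(hydroxymethyl)-1-methylethyl replaces cyclobutyl on a carbonyl carbon. Among these compounds, the value thus depends strongly on the group held here, a link the earlier compounds, differing in more than one place, could not show. Nothing shown gives a cause for this step. The change adds a hydroxyl and removes the four-membered ring at once, so their shares remain unseparated. From the compounds shown here alone, how an amine or a carboxylic acid in place of that hydroxyl would read also stays open.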